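Chloro walk on the thiazole–pyrimidinone series

The source may hold more compounds than are shown below. What is called first, only, known or untested is meant among the compounds shown, and "the series" means these compounds.

Measured so far in a functional assay on U-87MG ATCC cells for antiproliferative activity against U-87 MG (Homo sapiens), read by MTT assay, with a stated time of 48 h, tested at 5 uM; on this read-out higher numbers stand for a weaker effect at the one concentration tested and lower numbers for a stronger effect:
compound 1 `COc1ccc(-c2nc(C)c(C(=O)CSc3nc(-c4ccc(Cl)c(Cl)c4)c(C#N)c(=O)[nH]3)s2)cc1` gives 101%
compound 2 `Cc1nc(-c2ccccc2)sc1C(=O)CSc1nc(-c2ccccc2)c(C#N)c(=O)[nH]1` gives 92.1%
compound 3 `Cc1nc(-c2ccc(Cl)cc2)sc1C(=O)CSc1nc(-c2ccccc2)c(C#N)c(=O)[nH]1` gives 88.9%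

Compound 3 stands lowest of the three numbers in this assay; compound 2 lies nearest and within the scatter, compound 1 furthest and beyond it. Compound 4 `Cc1nc(-c2ccc(Cl)cc2)sc1C(=O)CSc1nc(-c2cccc(Cl)c2)c(C#N)c(=O)[nH]1` differs from compound 3 by chloro in place of hydrogen on an aromatic carbon. Within the data shown here, the only measured step of the same kind is a number 3.2 percentage points lower from compound 2 to compound 3 (within the scatter), a chloro in place of hydrogen on an aromatic carbon that changed nothing beyond the scatter. On that basis no step beyond the scatter is expected for compound 4, with a number 2.9 percentage points lower from compound 3 to compound 4 (within the scatter) at most a small drift lower. Compound 4 is therefore estimated at 86%, within 74% to 98%.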

Compound 4, a percentage reported as activity, at one concentration (the size of the read-out at that concentration, not a potency): 80.2%
For compound 4 the middle estimate is 5.8 percentage points above the measured one, within the range that was stated.
By their numbers in this assay, from the lowest: compounds 4, 3, 2 and 1 (each within the scatter of the next, the first and the last beyond it).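

In this assay the change from phenyl to 3-chlorophenyl, meta to a large group, gives a number 8.7 percentage points lower from compound 3 to compound 4 (within the scatter) and so stays short of a clear change at this second aromatic position. Together with a number 3.2 percentage points lower from compound 2 to compound 3 (within the scatter) this makes two chloro replacements on separate aromatic rings, neither beyond the scatter. No measured evidence bears on the reason for either step.

From the compounds shown here alone, whether an amine or a carboxylic acid in place of the hydrogen at this position would move the number beyond the scatter remains open. Also open, going by these compounds, is how a methoxy group here would compare with chloro.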